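A few compounds are considered here, and "the series" means these few. Any claim that something is new, unique, unknown or untested is made for them only; others in the source may bear on it.

Measured compounds:
compound 1 `Nc1ccccc1NC(=O)c1ccc(CSC(=S)N2CCN(Cc3ccccn3)CC2)cc1` — 65.2%
compound 2 `CN(C(=S)SCc1ccc(C(=O)Nc2ccccc2N)cc1)c1cccnc1` — 82.5%
compound 3 `CCN(Cc1ccncc1)C(=S)SCc1ccc(C(=O)Nc2ccccc2N)cc1` — 85.2%

All three were read in a functional assay on MGC-803 cells (Homo sapiens) for antiproliferative activity, read by CCK-8 assay, with a stated time of 72 h, tested at 8 uM; a lower number here means a weaker effect, a higher number a stronger effect of the compound at the concentration tested. Compound 1 gives the lowest of the three numbers; its gaps to compound 2 and to compound 3 are both beyond the usual scatter, so compound 1 does stand below the other two. For the measured compounds named here, compounds 2 and 3 differ from each other only on the thiocarbonyl carbon, and the one measured step, a number 2.7 percentage points higher from compound 2 to compound 3 (within the scatter), lies within the scatter.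

Compound 4 `Cc1ccc(N2CCN(C(=S)SCc3ccc(C(=O)Nc4ccccc4N)cc3)CC2)cc1` is not yet measured. It differs from compound 1 as follows:
4-methylphenyl in place of (pyridin-2-yl)methyl on an amine nitrogen in a ring

Going by the values given here, no measured step changes the substituent on the ring nitrogen of the six-membered non-aromatic ring with two nitrogens, so nothing here speaks directly to this change. Among the compounds with values here, the only step available, from compound 2 to compound 3, concerns a different site and was within the scatter; it suggests only that swapping one nitrogen-bearing group for another at the thiocarbonyl end does not move the read-out much. For the change from compound 1 to compound 4 there is therefore no firm basis for a direction. Compound 4 is expected at 70%, within 55% to 85%, so the estimated step of a number 4.8 percentage points higher from compound 1 to compound 4 (within the scatter) is expected to be small and uncertain in sign.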

Compound 4, a percentage reported as inhibition, at one concentration (the size of the read-out at that concentration, not a potency): 19.8%
The estimate for compound 4 lay 50.2 percentage points above the measured number; the measured number lies below the stated range.
By their numbers in this assay, from the lowest: compound 4; then compound 1; then compounds 2 and 3 (each within the scatter of the next).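

In this assay, for the compounds shown here, putting 4-methylphenyl in place of (pyridin-2-yl)methyl on the amine nitrogen in the ring gives a number 45.4 percentage points lower from compound 1 to compound 4 (beyond the scatter) and shows that this position, which no earlier step touched, can carry a large change in the read-out. Going by these compounds alone, the earlier step at the thiocarbonyl carbon stayed within the scatter, so this is the first site where a single exchange clearly matters, even though both groups have the same heavy-atom count and one six-membered aromatic ring each. The exchange removes the ring hetero atom and the hydrogen-bond acceptor and also changes how the aromatic ring is attached and substituted, and nothing available explains why the read-out falls.

A benzyl group or a pyridin-2-yl group on the same nitrogen would help separate the role of the ring nitrogen from that of the methylene link and the methyl substituent. Going by these compounds, it also remains open whether a 4-methylpyridinyl group or an unsubstituted phenyl group would hold the read-out nearer to that of compound 1 or of compound 4.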